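Shorter chains on the ring amide nitrogen: compound 4

The source may hold more compounds than are shown below. What is called first, only, known or untested is meant among the compounds shown, and "the series" means these compounds.

Measured so far:
- compound 1 `O=C(O)c1cc(-c2cccc(COc3ccc4c(c3)CN(Cc3ccc(C(F)(F)F)cc3)C4=O)c2)ccc1Cl` gives 350 nM in an assay on HEK293 cells for positive allosteric modulation of metabotropic glutamate receptor 2 (Rattus norvegicus), read by thallium flux; on this read-out higher numbers stand for an effect only at larger amounts of compound and lower numbers for an effect already at smaller amounts
- compound 2 `CC(C)N1Cc2cc(OCc3cccc(-c4ccc(Cl)c(C(=O)O)c4)c3)ccc2C1=O` gives 70 nM in this assay
- compound 3 `CC(C)CCN1Cc2cc(OCc3cccc(-c4ccc(Cl)c(C(=O)O)c4)c3)ccc2C1=O` gives 60 nM in this assay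

Compound 1 carries the highest number of the three. Its nearest neighbour is compound 2, with a 5.0-fold lower number from compound 1 to compound 2 (0.70 log units; beyond the scatter); compound 3 lies a little further away, with a 5.8-fold lower number from compound 1 to compound 3 (0.77 log units; beyond the scatter). Between the two smaller chains themselves the difference is a 1.2-fold lower number from compound 2 to compound 3 (0.07 log units; within the scatter), so those two cannot be told apart.

Compound 4 `CCCN1Cc2cc(OCc3cccc(-c4ccc(Cl)c(C(=O)O)c4)c3)ccc2C1=O` differs from compound 1 by ethyl in place of 4-(trifluoromethyl)phenyl on a saturated chain carbon bound to an amide-type nitrogen in a ring. The two steps that bear on this change are those from the same large group to a chain: a 5.0-fold lower number from compound 1 to compound 2 (0.70 log units; beyond the scatter) and a 5.8-fold lower number from compound 1 to compound 3 (0.77 log units; beyond the scatter). Both were beyond the scatter, both of similar size and in the same direction, and the step of a 1.2-fold lower number from compound 2 to compound 3 (0.07 log units; within the scatter) indicates that the exact shape of the chain did not matter between isopropyl and isopentyl. Propyl is a chain of the same kind rather than a ring-bearing group, so a step of that same modest size, downward, is expected for compound 4: a 5.0-fold lower number from compound 1 to compound 4 (0.70 log units; beyond the scatter). Compound 4 is therefore estimated at 70 nM, with a range from 30 nM to 160 nM.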

Compound 4, half-maximal effective concentration: > 10000 nM
Compound 4 ended at the assay's limit; the forecaster's own chance of this, stated with the estimate: 2%; middle value at least 140-fold (2.15 log units) away from the limit.
By their numbers in this assay, from the lowest: compounds 3 and 2 (each within the scatter of the next); then compound 1. At a limit, above all of these: compound 4.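

In this assay, compound 4 stands at a limit of the read-out and not at a number: the limit of > 10000 nM in this assay, at which 1 of the 4 values shown sits. The earlier compounds shown here gave no sign that the chain on the amide-type nitrogen could matter this much, yet propyl stands apart from both isopropyl and isopentyl, with an at least 140-fold higher number from compound 2 to compound 4 (2.15 log units; beyond the scatter) and an at least 160-fold higher number from compound 3 to compound 4 (2.22 log units; beyond the scatter), although those two were within the scatter of each other, with a 1.2-fold lower number from compound 2 to compound 3 (0.07 log units; within the scatter). Even the 4-(trifluoromethyl)benzyl group gives a lower number than propyl, with an at least 28-fold higher number from compound 1 to compound 4 (1.45 log units; beyond the scatter), so at this position neither the size of the group nor its being a simple chain predicts the result across these compounds, and compound 4 goes against the reading that any small chain serves.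

From the compounds shown here alone, how far the true value of compound 4 lies beyond the limit stays open, as does whether the loss belongs to propyl alone or to straight chains in general. An ethyl, a butyl or a longer straight chain on the same nitrogen, or a cyclopropyl there, would separate those readings, and the compounds shown give no answer for any of them.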